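A few compounds are considered here, and "the series" means these few. Any claim that something is new, unique, unknown or untested is made for them only; others in the source may bear on it.

Compound 2 `CCN1CCN(c2nc(Nc3ccc(C(=O)NC4CC(C)(C)N([O])C(C)(C)C4)cc3)ncc2[N+](=O)[O-])CC1` gives the highest of the three numbers recorded in a functional assay on HepG2 cells (Homo sapiens) for antiproliferative activity, read by MTT assay, with a stated time of 48 h (on this read-out lower numbers stand for stronger inhibition and higher numbers for weaker inhibition), at 56800 nM. Compound 1 `CC1(C)CC(NC(=O)c2ccc(Nc3ncc([N+](=O)[O-])c(NC4CCCC4)n3)cc2)CC(C)(C)N1[O]` gives 28700 nM, and compound 3 `CC1(C)CC(NC(=O)c2ccc(Nc3ncc([N+](=O)[O-])c(N4CCN(c5ccc(F)cc5)CC4)n3)cc2)CC(C)(C)N1[O]` gives 13100 nM. The step of a 2.0-fold higher number from compound 1 to compound 2 (0.30 log units; within the scatter) lies within the scatter, whereas the step of a 4.3-fold lower number from compound 2 to compound 3 (0.64 log units; beyond the scatter) lies beyond it. Compound 4 `Cc1cc(Nc2nc(Nc3ccc(C(=O)NC4CC(C)(C)N([O])C(C)(C)C4)cc3)ncc2[N+](=O)[O-])n[nH]1` differs from compound 2 by (5-methyl-1H-pyrazol-3-yl)amino in place of 4-ethylpiperazin-1-yl on an aromatic carbon. Both measured steps alter this same part of the molecule, and only the change toward compound 3 moved the number beyond the scatter, toward a lower value. A modest lowering is therefore expected, in the step of a 2.6-fold lower number from compound 2 to compound 4 (0.41 log units; beyond the scatter). Compound 4 is accordingly estimated at 22000 nM in this assay, with a range from 7000 nM to 60000 nM.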

Compound 4, half-maximal inhibitory concentration: 37500 nM
Estimate against measurement, compound 4: 1.7-fold (0.23 log units) below; measured number inside the range.
By their numbers in this assay, from the lowest: compound 3; then compounds 1, 4 and 2 (each within the scatter of the next).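

In this assay, the new group changes little at this position: a 1.5-fold lower number from compound 2 to compound 4 (0.18 log units; within the scatter) and a 1.3-fold higher number from compound 1 to compound 4 (0.12 log units; within the scatter) both stand within the scatter, so a five-membered aromatic ring carrying hydrogen-bond donors is not separated from either the 4-ethylpiperazin-1-yl or the cyclopentylamino group. Among the steps at this position, only a 4.3-fold lower number from compound 2 to compound 3 (0.64 log units; beyond the scatter) remains beyond the scatter. Nothing available explains this result. The compounds shown leave open whether the fluorine or the phenyl ring goes with the lower number of compound 3; a plain phenyl or a 4-chlorophenyl on the piperazine would bear on this.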